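The source may hold more compounds than are shown below. What is called first, only, known or untested is meant among the compounds shown, and "the series" means these compounds.

The series shares the core of compound 1 `COc1ccc2oc(CSC(=S)N3CCOCC3)cc(=O)c2c1`, which in a functional assay on LM7 cells (Homo sapiens) for antiproliferative activity, read by MTT assay, with a stated time of 72 h (on this read-out lower numbers stand for stronger inhibition and higher numbers for weaker inhibition), gives 11000 nM. Compound 3 `COc1ccc2oc(CSC(=S)N(C(C)C)C(C)C)cc(=O)c2c1` gives 19100 nM; the step of a 1.7-fold higher number from compound 1 to compound 3 (0.24 log units; within the scatter) leaves compound 3 within the scatter of compound 1. Compound 2 `O=c1cc(CSC(=S)N2CCCCC2)oc2ccccc12` returns only a limit, > 25000 nM, in this assay, see (the limit of > 25000 nM in this assay, at which 1 of the 3 values shown sits). Compound 4 `COc1ccc2oc(CSC(=S)N3CCCCC3)cc(=O)c2c1` differs from compound 3 by piperidin-1-yl in place of diisopropylamino on a thiocarbonyl carbon. Going by the values given here, the single measured step at the thiocarbonyl nitrogen, a 1.7-fold higher number from compound 1 to compound 3 (0.24 log units; within the scatter), stayed within the scatter, so no shift beyond the scatter is expected in this assay. Compound 4 is therefore estimated at 20000 nM (range 8000 nM to 50000 nM). This corresponds to an expected step of a 1.0-fold higher number from compound 3 to compound 4 (0.02 log units; within the scatter).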

Compound 4, half-maximal inhibitory concentration: 5000 nM
For compound 4 the middle estimate is 4.0-fold (0.60 log units) above the measured one, and the stated range ends above it.
By their numbers in this assay, from the lowest: compound 4; then compounds 1 and 3 (each within the scatter of the next). At a limit, above all of these: compound 2.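

At the thiocarbonyl carbon the choice of amine now shows an effect on the number: piperidin-1-yl gives a 3.8-fold lower number from compound 3 to compound 4 (0.58 log units; beyond the scatter) and, against morpholin-4-yl, a 2.2-fold lower number from compound 1 to compound 4 (0.34 log units; beyond the scatter), whereas the earlier step at this place stayed within the scatter. Methoxy in place of hydrogen on an aromatic carbon also shows a step for the first time, an at least 5.0-fold lower number from compound 2 to compound 4 (0.69 log units; beyond the scatter). That step rests on a limit for compound 2: the limit of > 25000 nM in this assay, at which 1 of the 4 values shown sits.

Still open, as far as these compounds go, is how a pyrrolidin-1-yl or 4-methylpiperazin-1-yl group on the thiocarbonyl carbon would compare with piperidin-1-yl. Also open, from the compounds shown here alone, is whether a hydroxy group or an amine in place of methoxy would keep that step.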